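The compounds below may be only part of what the source reports. "The series", "measured", "known", "first", "only" and "open" are said of these compounds alone.

Values so far in a functional assay on NCI-H1975 cells (Homo sapiens) for antiproliferative activity, with a stated time of 72 h; a lower number here means a stronger inhibitor of growth, a higher number a weaker inhibitor of growth
compound 1 `Cc1cccc(CN(C)C(=O)c2cc(Cl)c(O)cc2O)c1` gives 49300 nM
compound 2 `CCNC(=O)c1ccc(CN(C)C(=O)c2cc(Cl)c(O)cc2O)cc1` gives 21700 nM
compound 3 `CCNC(=O)c1ccc(CN(C)C(=O)c2cc(C(C)C)c(O)cc2O)cc1` gives 460 nM

For the measured compounds named here, compound 3 stands lowest of the three at 460 nM in this assay so far. Next comes compound 4 `CCCNC(=O)c1ccc(CN(C)C(=O)c2cc(C(C)C)c(O)cc2O)cc1` with the change methyl in place of hydrogen on a saturated chain carbon, two bonds along the chain from an amide-type nitrogen that reads ethyl to propyl, methyl in place of hydrogen on a saturated chain carbon, two bonds along the chain from an amide-type nitrogen. Going by the values given here, the only measured step is a 47-fold lower number from compound 2 to compound 3 (1.67 log units; beyond the scatter) and it is large, yet it puts isopropyl in place of chloro on an aromatic carbon and says nothing direct about this chain. Among the compounds with values here, no measured compound varies the ethyl group, so no step beyond the scatter is expected in this assay and the direction stays open. The estimated step is a 1.0-fold lower number from compound 3 to compound 4 (0.01 log units; within the scatter) with wide margins. Compound 4 is expected at 450 nM within an estimated range from 150 nM to 1300 nM as the likely span.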

Compound 4, concentration for 50% growth inhibition: 420 nM
Estimate against measurement, compound 4: 1.1-fold (0.03 log units) above; measured number inside the range.
By their numbers in this assay, from the lowest: compounds 4 and 3 (each within the scatter of the next); then compound 2; then compound 1.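

In this assay the ethyl to propyl change on the amide-type nitrogen gives a 1.1-fold lower number from compound 3 to compound 4 (0.04 log units; within the scatter) and is the only step shown on this chain. This one added methyl therefore stays within the scatter, unlike the large step at the aromatic carbon. Going by these compounds, whether a butyl chain, or a chain carrying an amine or a carboxylic acid, would read the same stays open. So does whether ethyl to propyl reads the same with chloro in place of isopropyl on the aromatic carbon. No measured property bears on this result.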